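The source may report more compounds than this note shows. Statements on the series, on what has been measured and on what is new or still open speak of the compounds shown alone.

Of the compounds shown here, three have so far been measured in a functional assay on DU-145 cells (Homo sapiens) for cytotoxicity, read by sulforhodamine B assay, with a stated time of 48 h, tested at 1 uM; a higher number here means a weaker effect of the compound at the concentration tested, a lower number a stronger effect. Compound 1 `COc1cc(C)cc(-c2c(-c3ccnc(-c4ccc(C(C)=O)cc4)c3)cnn2CC#N)c1` gives 16%. Compound 2 `Cc1cc(O)cc(-c2nn(CC#N)cc2-c2ccnc(-c3ccc(Oc4ccccc4)cc3)c2)c1` gives -14%. Compound 3 `COc1cc(C)cc(-c2nn(CC#N)cc2-c2ccnc(-c3ccc(N(C)C)cc3)c2)c1` gives -40%, the lowest of the three numbers: compound 2 lies nearest, with a number higher by more than the usual scatter, and compound 1 lies furthest, higher by well more than the scatter. No two of these three compounds differ in only one place, so no single structural change can be read off from them.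

Compound 4 `Cc1cc(O)cc(-c2nn(CC#N)cc2-c2ccnc(-c3ccc(N(C)C)cc3)c2)c1` is compound 3 with one change on the shared core, methoxy to hydroxy:

hydrogen in place of methyl on an oxygen on an aromatic ring

Compound 2 also carries the hydroxy, yet it differs from compound 3 in a second place too, so its number does not isolate this change. A small step toward a higher number is expected, a number 15 percentage points higher from compound 3 to compound 4 (beyond the scatter), not clearly beyond the scatter. Compound 4 is therefore expected to give about -25% in this assay, with a likely range from -55% to 5%.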

Compound 4, a percentage reported as activity, at one concentration (the size of the read-out at that concentration, not a potency): -7%
For compound 4 the middle estimate is 18 percentage points below the measured one; measured number inside the range.
By their numbers in this assay, from the lowest: compound 3; then compounds 2 and 4 (each within the scatter of the next); then compound 1.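

On the 3-methoxy-5-methylphenyl group, the change from methoxy to hydroxy can now be read on its own: in this assay it gives a number 33 percentage points higher from compound 3 to compound 4 (beyond the scatter), a large step, so the methyl on that oxygen clearly counts here. With the hydroxy kept, dimethylamino in place of phenoxy on an aromatic carbon gives a number 7 percentage points higher from compound 2 to compound 4 (within the scatter), so this pair does not separate the two groups. Nothing measured here explains either step.

Within the data shown here, whether the methoxy step holds when phenoxy or the group on the ring of compound 1 is present remains open, since only one pair isolates it. Also open, from the compounds shown here alone, is how a longer chain on that oxygen, such as ethoxy, or an amine in place of the hydroxy would behave.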